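The compounds below may be only part of what the source reports. "The series", "measured", "known", "first", "only" and "open" are said of these compounds alone.

Compound 1 `ClCc1cccc(Cn2cnc3c(Cl)ncnc32)c1`: 2340 nM
Compound 2 `ClCc1ccc(Cn2cnc3nc(Cl)nc(Cl)c32)cc1`: 1860 nM

In a functional assay on SN12C cells (Homo sapiens) for cytotoxicity, read by sulforhodamine B assay, with a stated time of 48 h (on this read-out lower numbers stand for stronger inhibition of growth and higher numbers for weaker inhibition of growth), compound 2 gives 1860 nM, and compound 1 gives 2340 nM; the gap between them lies within the scatter, so the two cannot be told apart. Compound 3 `ClCc1ccc(Cn2cnc3ncnc(Cl)c32)cc1` has not yet been measured. It differs from compound 2 by hydrogen in place of chloro on an aromatic carbon. Within the data shown here, no measured pair shows what such a removal does here, so no step beyond the scatter in either direction is expected in this assay. Compound 3 is therefore estimated at 2500 nM, in a range from 1000 nM to 6500 nM, which means an expected step of a 1.3-fold higher number from compound 2 to compound 3 (0.13 log units; within the scatter).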

Compound 3, concentration for 50% growth inhibition: 3630 nM
Beside the measured number, compound 3's estimate is 1.5-fold (0.16 log units) below it; the measured number falls inside the stated range.
By their numbers in this assay, from the lowest: compounds 2, 1 and 3 (each within the scatter of the next).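

Replacing the chloro group on the aromatic carbon between two ring nitrogen atoms with hydrogen gives a 2.0-fold higher number from compound 2 to compound 3 (0.29 log units; within the scatter) in this assay. Among these compounds, this is the first direct comparison at this position, and it shows that the chloro group can be removed without a change that stands clear of the scatter. Nothing available explains the size of this step.

Still open, as far as these compounds go, is whether an amine or a methoxy group at this position would shift the number beyond the scatter. The effect of replacing the remaining chloro group is also unknown.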